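The compounds below may be only part of what the source reports. "The series", "measured", "known", "first", "only" and "open" are said of these compounds alone.

Compound 1 `C=C1C[C@]23C[C@@]1(O)CC[C@H]2c1cc(Br)c(O)c(C)c1[C@@H]3Cn1cc(-c2ccc(C)cc2)nn1` gives in a functional assay on SMMC-7721 cells (Homo sapiens) for cytotoxicity, read by MTT assay, with a stated time of 4 days (on this read-out higher numbers stand for weaker inhibition and lower numbers for stronger inhibition), only a limit, > 20000 nM.
Compound 2 `C=C1C[C@]23C[C@@]1(O)CC[C@H]2c1cc(Br)c(O)c(C)c1[C@@H]3Cn1cc(-c2ccccc2)nn1` gives in this assay only a limit, > 20000 nM.
Compound 3 `C=C1C[C@]23C[C@@]1(O)CC[C@H]2c1ccc(O)c(C)c1[C@@H]3Cn1cc(-c2ccc(C(F)(F)F)cc2)nn1` gives in this assay only a limit, > 20000 nM.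

Compound 3 therefore stands where every measured value here stands: at the limit of > 20000 nM in this assay, at which 3 of the 3 values shown sit, with no number below it to place it against the other two. Going by the values given here, the one measured step, a step that the two limits leave unreadable from compound 1 to compound 2, is also a removal of a small group from the same kind of ring, but both of its ends are limits, so its size cannot be read.

Compound 4 `C=C1C[C@]23C[C@@]1(O)CC[C@H]2c1ccc(O)c(C)c1[C@@H]3Cn1cc(-c2ccccc2)nn1` has not yet been measured. It differs from compound 3 in one place: hydrogen in place of trifluoromethyl on an aromatic carbon.

No readable step bears on this change, and the three measured compounds all sit at the limit. The expectation for compound 4 in this assay is thus a step that the limit leaves unreadable from compound 3 to compound 4, nothing beyond the scatter, with compound 4 most likely returning a limit again. The estimate for compound 4 is 30000 nM, within a range of 10000 nM to 100000 nM.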

Compound 4, half-maximal inhibitory concentration: > 20000 nM
Compound 4: only a limit was reported; the forecaster's own chance of this, stated with the estimate: 85%; the middle value is on the limit's open side.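

Compound 4 also gives only a limit, > 20000 nM, so the steps to it from compound 3 and from compound 2 cannot be read: the limit of > 20000 nM in this assay, at which 4 of the 4 values shown sit.

Whether trifluoromethyl, bromo or methyl changes the result in this assay at all stays open, since none of these compounds has a value that is an actual number.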